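Acyl group variation on a dimethylaminophenyl pyrazoline scaffold

A few compounds are considered here, and "the series" means these few. Any claim that something is new, unique, unknown or untested is made for them only; others in the source may bear on it.

Of the compounds shown here, three sharing one core have been tested in a functional assay on MDA-MB-231 cells (Homo sapiens) for inhibition, read by sulforhodamine B assay, tested at 10 uM; a lower number here means less inhibition, a higher number more inhibition at the concentration tested (going by the name of the read-out). Compound 1 `CN1CCN(c2ccc(C3=NN(C(=O)/C=C/c4ccccc4)C(c4ccc(N(C)C)cc4)C3)cc2)CC1` gives 35.9%. Compound 2 `CN(C)c1ccc(C2CC(c3ccc(-n4ccnc4)cc3)=NN2C(=O)CCCl)cc1` gives 2.1%. Compound 3 `C=C(C)C(=O)N1N=C(c2ccc(-n3ccnc3)cc2)CC1c1ccc(N(C)C)cc1` gives 4.3%, which places it second highest of the three: its nearest neighbour is compound 2, and the step of a number 2.2 percentage points higher from compound 2 to compound 3 (within the scatter) lies within the scatter, while compound 1 stands beyond the scatter above it.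

Compound 4 `CN(C)c1ccc(C2CC(c3ccc(-n4ccnc4)cc3)=NN2C(=O)c2cc(Cl)cc(Cl)c2)cc1` has not yet been measured. It differs from compound 3 by 3,5-dichlorophenyl in place of 1-methylethenyl on a carbonyl carbon. Within the data shown here, the only measured step at the same carbonyl carbon, a number 2.2 percentage points higher from compound 2 to compound 3 (within the scatter), was within the scatter, so an exchange of the group on that carbonyl has so far moved the read-out little. Compound 1 carries a different acyl group and also a different aryl substituent, so its higher value cannot be tied to the acyl group alone.

On this basis the step of a number 7.7 percentage points higher from compound 3 to compound 4 (within the scatter) is expected to stay modest. The estimate for compound 4 is 12%, with a range from 0% to 32%.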

Compound 4, a percentage reported as inhibition, at one concentration (the size of the read-out at that concentration, not a potency): 48.8%
Compound 4: middle estimate off by 36.8 percentage points, on the low side; measured number above the stated range.
By their numbers in this assay, from the lowest: compounds 2 and 3 (each within the scatter of the next); then compound 1; then compound 4.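

In this assay, the group on this carbonyl carbon does matter: the step of a number 44.5 percentage points higher from compound 3 to compound 4 (beyond the scatter) and the step of a number 46.7 percentage points higher from compound 2 to compound 4 (beyond the scatter) are both large, whereas the step of a number 2.2 percentage points higher from compound 2 to compound 3 (within the scatter) stayed within the scatter. Among compound 2, compound 3 and compound 4, which differ only in this group, the read-out separates only where 3,5-dichlorophenyl, with its six-membered aromatic ring and two chlorine atoms, replaces 2-chloroethyl or 1-methylethenyl. No evidence is available on why the step is so large.

The compounds shown do not separate the contribution of the aromatic ring from that of its two chlorine atoms, which an unsubstituted phenyl on the same carbonyl would address. Also open, from the compounds shown here alone, is whether a saturated ring such as cyclohexyl, or a phenyl carrying methoxy groups, would give a similar read-out.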